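Trading a Linker Carbon for Two Ring Methyls

A few compounds are considered here, and "the series" means these few. Any claim that something is new, unique, unknown or untested is made for them only; others in the source may bear on it.

Compound 1 `N#Cc1cnc(NCc2cnccc2C(F)(F)F)cc1NC[C@H]1CC[C@H](O)CC1`: 2000 nM
Compound 2 `N#Cc1cnc(NCc2cnccc2C(F)(F)F)cc1N[C@H]1CC[C@@H](c2nc[nH]n2)CC1`: 1200 nM
Compound 3 `CC(C)(C)Oc1ncncc1CNc1cc(N[C@H]2CC[C@@H](O)CC2)c(C#N)cn1`: 200 nM

Of the compounds shown here, three share a core and have been tested in an assay on isolated protein for inhibition of protein kinase C delta type (Homo sapiens), read by TR-FRET, with a stated time of 2 h; on this read-out higher numbers stand for weaker inhibition and lower numbers for stronger inhibition. Compound 1 gives 2000 nM, the highest of the three numbers. Compound 2 sits within the usual scatter of compound 1, so the two cannot be told apart. Compound 3, with a different group on the other side of the core and its hydroxycyclohexyl ring set on the nitrogen without a methylene, lies beyond the scatter below compound 1.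

Compound 4 `CC1(C)C[C@H](Nc2cc(NCc3cnccc3C(F)(F)F)ncc2C#N)CC[C@H]1O` has not yet been measured. It differs from compound 1 in one place: 4-hydroxy-3,3-dimethylcyclohexyl in place of (4-hydroxycyclohexyl)methyl on a nitrogen on an aromatic ring. The ring is now joined to the nitrogen without the intervening carbon, and carries two extra methyls beside the hydroxyl.

Compounds 2 and 3, which lack the methylene link, both give lower numbers than compound 1, so a downward step is expected, of a size beyond the scatter a 4.0-fold lower number from compound 1 to compound 4 (0.60 log units; beyond the scatter). Compound 4 is estimated at 500 nM, in a range from 150 nM to 1500 nM.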

Compound 4, half-maximal inhibitory concentration: 2200 nM
Compound 4: the middle estimate sits 4.4-fold (0.64 log units) below what was measured; measured number above the stated range.
By their numbers in this assay, from the lowest: compound 3; then compounds 2, 1 and 4 (each within the scatter of the next).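

In this assay, exchanging (4-hydroxycyclohexyl)methyl for 4-hydroxy-3,3-dimethylcyclohexyl on a nitrogen on an aromatic ring gives a 1.1-fold higher number from compound 1 to compound 4 (0.04 log units; within the scatter), so this pair shows no measurable change. For the compounds shown here, it is the first comparison here that differs in only one place, and it shows that removing the linking carbon and adding the two methyls, taken together, leave the number at this position indistinguishable from that of compound 1. No supporting data bear on why this exchange produces so little difference.

Because the two alterations arrive together, the compounds shown cannot tell whether each alone does nothing or whether their separate effects offset one another. Going by these compounds, how a 4-aminocyclohexyl group on this nitrogen of the shared core would read also remains open.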